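The compounds below may be only part of what the source reports. "The series", "measured", "known", "first", "only" and "open" are said of these compounds alone.

Measured so far:
compound 1, `Cc1ccc(/C=C/C(=O)/C=C(O)/C=C/c2ccc(C)o2)o1`: > 25000 nM
compound 2, `COc1ccc(/C=C/C(=O)C(=Cc2cccc(F)c2)C(=O)/C=C/c2ccc(OC)c(OC)c2)cc1OC`: 580 nM

In a functional assay on A549 cells (Homo sapiens) for inhibition, read by sulforhodamine B assay, with a stated time of 48 h (on this read-out lower numbers stand for stronger inhibition of growth and higher numbers for weaker inhibition of growth), compound 1 gives only a limit, > 25000 nM. In this assay, among the measured compounds shown here, compound 2 gives 580 nM, the only number so far. The value of compound 1 is a limit, as the limit of > 25000 nM in this assay, at which 1 of the 2 values shown sits, shows. Compound 3, `COc1ccc(OC)c(C=C(C(=O)/C=C/c2ccc(OC)c(OC)c2)C(=O)/C=C/c2ccc(OC)c(OC)c2)c1`, has not yet been measured. It differs from compound 2 in one place: 2,5-dimethoxyphenyl in place of 3-fluorophenyl on a double-bonded chain carbon bound to a double-bonded chain carbon. No measured pair of compounds differs in one place, so the series itself gives no scale for this change, and the measured values offer no reason to expect a large shift in either direction. The expected step in this assay is a 1.4-fold higher number from compound 2 to compound 3 (0.14 log units; within the scatter), small, within the usual scatter, leaning slightly toward weaker inhibition of growth. For compound 3 the estimate in this assay is 800 nM, with a range from 250 nM to 2500 nM.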

Compound 3, concentration for 50% growth inhibition: 530 nM
Compound 3: the middle estimate sits 1.5-fold (0.18 log units) above what was measured; the range from low to high includes it.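

In this assay, 2,5-dimethoxyphenyl in place of 3-fluorophenyl on a double-bonded chain carbon bound to a double-bonded chain carbon gives a 1.1-fold lower number from compound 2 to compound 3 (0.04 log units; within the scatter). Among the compounds shown here, this is the first scale for a change at this place: a group of 10 heavy atoms with 2 hydrogen-bond acceptors replaces one of 7 heavy atoms with none, and the step stays within the scatter, so the series tolerates this particular exchange in this read-out. No measured property shown bears on the size of this step.

On these data alone, a single step cannot separate the loss of the fluorine from the gain of the two methoxy groups, so their individual contributions remain unknown. As far as these compounds go, it also remains open whether an aliphatic amine or a carboxylic acid at this place would be tolerated as well.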